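Stripping the 1,3-thiazol-2-yl group from compound 2

The compounds below may be only part of what the source reports. "The series", "measured", "known", "first", "only" and "open" are said of these compounds alone.

Among the measured compounds shown here, in a functional assay on HeLa cells (Homo sapiens) for antiproliferative activity, read by sulforhodamine B assay, with a stated time of 72 h (a higher number here means a weaker inhibitor, a lower number a stronger inhibitor), compound 2 `O=S(=O)(Nc1nccs1)c1ccc(Nc2nncc3ccccc23)cc1` gives 15 nM and so holds the lower of the two numbers measured so far. In this assay compound 1 `CCN1C(=O)CS/C1=N/Nc1nncc2ccccc12` stands at 65 nM with a gap to compound 2 that lies beyond the scatter. For the measured compounds named here, these two compounds differ in more than one place, so no measured step speaks to a single structural change.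

Compound 3 `NS(=O)(=O)c1ccc(Nc2nncc3ccccc23)cc1` has not yet been measured. Going from compound 2 to compound 3 means hydrogen in place of 1,3-thiazol-2-yl on a sulfonamide nitrogen, with hydrogen in place of 1,3-thiazol-2-yl on a sulfonamide nitrogen as the full count of the change. Going by the values given here, with no measured precedent for this edit, the expectation rests on the standing of compound 2 at 15 nM as the lower of the two numbers, which makes an upward move the likelier direction. The estimated step of a 3.3-fold higher number from compound 2 to compound 3 (0.52 log units; beyond the scatter) is expected to exceed the scatter modestly and to give a weaker inhibitor in this assay with real uncertainty attached. For compound 3 the expected value is 50 nM within an estimated range from 12 nM to 250 nM in four of five measurements.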

Compound 3, half-maximal inhibitory concentration: 12 nM
For compound 3 the middle estimate is 4.2-fold (0.62 log units) above the measured one; the measured number falls inside the stated range.
By their numbers in this assay, from the lowest: compounds 3 and 2 (each within the scatter of the next); then compound 1.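

Putting hydrogen in place of the 1,3-thiazol-2-yl group on the sulfonamide nitrogen gives a 1.3-fold lower number from compound 2 to compound 3 (0.10 log units; within the scatter) in this assay, and this is the only single-place change among the compounds shown. The two compounds cannot be told apart here, so at this position the whole five-membered aromatic ring can be lost without the number leaving the scatter, and the 1,3-thiazol-2-yl group is not required for a value of this size, as compound 3 shows with its unsubstituted sulfonamide at 12 nM. No measured finding accompanies this result to explain why the two compounds match.

On these data alone, what remains open is whether this nitrogen accepts other groups equally well, for example a methyl, an acetyl or a pyridin-2-yl ring, or whether the match holds only for the 1,3-thiazol-2-yl group and hydrogen. Also open, as far as these compounds go, is how much the sulfonamide itself contributes, which a carboxylic acid or a carboxamide in its place would address, and compound 1 cannot answer this, since it differs from both other compounds in more than one place.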